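The source may hold more compounds than are shown below. What is called first, only, known or untested is meant among the compounds shown, and "the series" means these compounds.

Compound 2 `COc1cc(-c2nn(-c3cccc(NC(=O)Nc4ccc(Cl)c(C(F)(F)F)c4)c3)cc2-c2ccncc2)ccc1Cl` gives 884 nM in a functional assay on SR cells (Homo sapiens) for inhibition, read by sulforhodamine B assay, with a stated time of 48 h (on this read-out lower numbers stand for stronger inhibition of growth and higher numbers for weaker inhibition of growth), one of two numbers shown, and stands within the scatter of compound 1 `COc1cc(-c2nn(-c3cccc(NC(=O)Nc4ccc(Cl)c(Cl)c4)c3)cc2-c2ccncc2)ccc1Cl`, which gives 932 nM. The step of a 1.1-fold lower number from compound 1 to compound 2 (0.02 log units; within the scatter) covers only the swap of chloro for trifluoromethyl. Compound 3 `COc1cc(-c2nn(-c3cccc(NC(=O)c4ccccc4)c3)cc2-c2ccncc2)ccc1Cl` differs from compound 2 by phenyl in place of (4-chloro-3-(trifluoromethyl)phenyl)amino on a carbonyl carbon. Among the measured compounds shown here, no measured step bears on this change; the single available step a 1.1-fold lower number from compound 1 to compound 2 (0.02 log units; within the scatter) alters a substituent on the very ring that now leaves. The expected step of a 3.4-fold higher number from compound 2 to compound 3 (0.53 log units; beyond the scatter) therefore carries wide uncertainty. Compound 3 is expected to give 3000 nM, in the range 700 nM to 15000 nM.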

Compound 3, concentration for 50% growth inhibition: 250 nM
Estimate against measurement, compound 3: 12-fold (1.08 log units) above; measured number below the stated range.
By their numbers in this assay, from the lowest: compound 3; then compounds 2 and 1 (each within the scatter of the next).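

In this assay, the earlier swap on the outer ring moved the number only within the scatter, whereas changing the group on the carbonyl carbon moves it beyond the scatter. Phenyl in place of (4-chloro-3-(trifluoromethyl)phenyl)amino brings a 3.5-fold lower number from compound 2 to compound 3 (0.55 log units; beyond the scatter) and phenyl in place of (3,4-dichlorophenyl)amino brings a 3.7-fold lower number from compound 1 to compound 3 (0.57 log units; beyond the scatter) so both changes point the same way, towards stronger inhibition of growth. The compounds shown leave open how a methoxy group or an amine on the entering phenyl, or a cyclohexyl ring in its place, would read. No measurement at hand accounts for the shift.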